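The compounds below may be only part of what the source reports. "The series", "measured", "known", "first", "only" and "open" are said of these compounds alone.

Compound 1 `c1ccc(-c2n[nH]cc2N2CCNCC2)cc1` in an assay on isolated protein for binding affinity to 5-hydroxytryptamine receptor 4 (Homo sapiens) (a higher number here means a weaker inhibitor, a lower number a stronger inhibitor), gives > 10000 nM, which is a limit of the assay rather than a number. Compound 2 `Clc1ccc(-c2n[nH]cc2N2CCNCC2)cc1` in this assay gives > 10000 nM, again a limit. The step that the two limits leave unreadable from compound 1 to compound 2 cannot be read, since the limit of > 10000 nM in this assay, at which 2 of the 2 values shown sit, shows both values resting there. Compound 2 thus stands only at the edge of what this assay can report. Compound 3 `Fc1ccc(-c2n[nH]cc2N2CCNCC2)cc1` differs from compound 2 by fluoro in place of chloro on an aromatic carbon. No measured step bears on swapping one halogen for another here, and the single step shown has no readable size. Compound 3 is therefore expected to stay beyond the limit, estimated at 20000 nM with a range from 5000 nM to 100000 nM, an expected step that the limit leaves unreadable from compound 2 to compound 3.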

Compound 3, inhibition constant: > 10000 nM
Compound 3: only a limit was reported; the forecaster's own chance of this, stated with the estimate: 85%; the middle value is on the limit's open side.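

Compound 3 gives > 10000 nM in this assay, which is again a limit, so no step among compound 1, compound 2 and compound 3 can be read: the limit of > 10000 nM in this assay, at which 3 of the 3 values shown sit.

The compounds shown leave open how strongly any of the three binds, and whether any substituent at this ring position changes that.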